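Swapping a dichlorophenyl for a furan on a shared core

The source may hold more compounds than are shown below. What is called first, only, known or untested is meant among the compounds shown, and "the series" means these compounds.

Measured compounds:
- compound 1, `CN(CC1=CC[C@H]2C[C@@H]1C2(C)C)Cc1ccc(-c2cccc(Cl)c2)cc1`: 3980 nM
- compound 2, `CN(CC1=CC[C@H]2C[C@@H]1C2(C)C)Cc1ccc(-c2cc(Cl)cc(Cl)c2)cc1`: > 316 nM

Both compounds were tested in an assay on HEK293 cells for displacement of a labelled ligand from C-X-C chemokine receptor type 3 (Homo sapiens); on this read-out higher numbers stand for weaker inhibition and lower numbers for stronger inhibition. Compound 1 gives 3980 nM in this assay. For compound 2 this assay reports only a limit, > 316 nM, so its exact position is not known. Going by the values given here, the one measured step, a step that the limit leaves unreadable from compound 1 to compound 2, cannot be read in size for the same reason, as the only evidence on it is the limit of > 316 nM in this assay, at which 1 of the 2 values shown sits.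

Compound 3, `CN(CC1=CC[C@H]2C[C@@H]1C2(C)C)Cc1ccc(-c2ccoc2)cc1`, has not yet been measured. It differs from compound 2 in one place: furan-3-yl in place of 3,5-dichlorophenyl on an aromatic carbon, on an aromatic carbon of a six-membered aromatic ring of carbon only, para to a large group. Among the compounds with values here, no measured step concerns this kind of exchange, and the one step that exists is unreadable, so the direction of this assay cannot be predicted from the data. The expected step that the limit leaves unreadable from compound 2 to compound 3 is therefore an estimate without a measured anchor. Compound 3 is expected to give about 3000 nM in this assay, within a range from 800 nM to 12000 nM.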

Compound 3, inhibition constant: 6310 nM
Estimate against measurement, compound 3: 2.1-fold (0.32 log units) below; the measured number falls inside the stated range.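

In this assay, going by these compounds alone, compound 3 gives the first readable comparison at this position, on an aromatic carbon of a six-membered aromatic ring of carbon only, para to a large group. Replacing 3-chlorophenyl with furan-3-yl gives a 1.6-fold higher number from compound 1 to compound 3 (0.20 log units; within the scatter), so the five-membered oxygen ring and the chlorinated six-membered ring cannot be told apart on this read-out. Compound 2 has only a limit, so neither step involving it can be read: the limit of > 316 nM in this assay, at which 1 of the 3 values shown sits.

On these data alone, it remains open whether the 3,5-dichlorophenyl group of compound 2 truly differs from the groups in compound 1 and compound 3. As far as these compounds go, it is also open whether a group of another kind at this position, such as a carboxylic acid or an amine, would move the number beyond the usual scatter.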